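A few compounds are considered here, and "the series" means these few. Any claim that something is new, unique, unknown or untested is made for them only; others in the source may bear on it.

Measured compounds:
compound 1, `NC(=O)c1cnc2ccc(-c3cccnc3)cc2c1NC1CCCCC1` — 132 nM
compound 2, `C[C@@H](Nc1c(C(N)=O)cnc2ccc(-c3cccnc3)cc12)C1CCOCC1` — 730 nM

In an assay on HT-29 cells for inhibition of Serine-protein kinase ATM (Homo sapiens), read by fluorescence, with a stated time of 1 h (on this read-out higher numbers stand for weaker inhibition and lower numbers for stronger inhibition), compound 1 gives 132 nM and compound 2 gives 730 nM. Compound 2 therefore carries the highest number of the two measured; its nearest neighbour is compound 1, and the step of a 5.5-fold higher number from compound 1 to compound 2 (0.74 log units; beyond the scatter) separates them. Within the data shown here, that single step, 1-(oxan-4-yl)ethyl in place of cyclohexyl on a nitrogen on an aromatic ring, is the only measured comparison.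

Compound 3, `C[C@H](Nc1c(C(N)=O)cnc2ccc(-c3cccnc3)cc12)C1CCOCC1`, is the next compound. Its relation to compound 2: the two compounds have the same atoms and bonds and differ only in configuration as drawn: 1 of 1 stereo elements differ; a stereocentre at a saturated chain carbon is drawn R in compound 2 and S in compound 3. Among the measured compounds shown here, no measured step concerns a change of configuration alone, so the step from compound 1 to compound 2 does not bear directly on it; it only shows that the substituent on the ring nitrogen matters beyond the scatter. With the two drawn configurations differing and nothing else, the direction of the step in this assay is open: the number could fall toward that of compound 1 or rise further. The estimate for compound 3 is placed at 450 nM, with a wide range from 60 nM to 3500 nM, corresponding to an expected step of a 1.6-fold lower number from compound 2 to compound 3 (0.21 log units; within the scatter) that is not confidently beyond the scatter in either direction.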

Compound 3, half-maximal inhibitory concentration: 168 nM
Beside the measured number, compound 3's estimate is 2.7-fold (0.43 log units) above it; low and high end bracket the measured number.
By their numbers in this assay, from the lowest: compounds 1 and 3 (each within the scatter of the next); then compound 2.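

In this assay, the configuration at the saturated chain carbon matters on its own, with a 4.3-fold lower number from compound 2 to compound 3 (0.64 log units; beyond the scatter), and the gap can be assigned to that single stereocentre because nothing else in the pair changes: the fact that compounds 2 and 3 differ only in the configuration as drawn

This qualifies the earlier reading of the substituent on the nitrogen, since the penalty seen in a 5.5-fold higher number from compound 1 to compound 2 (0.74 log units; beyond the scatter) belongs to the form drawn R and does not follow from the 1-(oxan-4-yl)ethyl group as such. With the form drawn S, the same replacement of cyclohexyl gives a 1.3-fold higher number from compound 1 to compound 3 (0.10 log units; within the scatter), so that form of the group is not separated from cyclohexyl in this read-out.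

The compounds shown do not separate the part played by the methyl branch from that of the ring oxygen, a question that a plain oxan-4-yl or a 1-cyclohexylethyl group on the nitrogen would address. Going by these compounds, whether the form drawn S keeps its advantage over the form drawn R with another branched group, such as 1-phenylethyl, also remains open.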